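A few compounds are considered here, and "the series" means these few. Any claim that something is new, unique, unknown or untested is made for them only; others in the source may bear on it.

Measured in a functional assay on A549 cells (Homo sapiens) for cytotoxicity, read by MTT assay, with a stated time of 72 h; on this read-out higher numbers stand for weaker inhibition and lower numbers for stronger inhibition:
Compound 1 `CNC(=O)c1cc(Oc2ccc(NC(=O)c3cc(-c4ccc(Cl)cc4)ncn3)cc2F)ccn1`: > 100000 nM
Compound 2 `CNC(=O)c1cc(Oc2ccc(NC(=O)c3cc(-c4ccc(Cl)cc4)ncn3)cc2)ccn1`: > 100000 nM

Both entries are limits of the assay and not numbers. As far as these compounds go, compound 2 stands at > 100000 nM, which is a limit, so its exact position is unknown. The same holds across the small set, which shows (the limit of > 100000 nM in this assay, at which 2 of the 2 values shown sit).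

Compound 3 `CNC(=O)c1cc(Oc2ccc(NC(=O)c3cc(-c4ccc(OC)cc4)ncn3)cc2)ccn1` differs from compound 2 at a single place, with the 4-chlorophenyl becoming 4-methoxyphenyl: methoxy in place of chloro on an aromatic carbon. This is methoxy in place of chloro on an aromatic carbon. Going by the values given here, the only measured step, a step that the two limits leave unreadable from compound 1 to compound 2, is a different change, hydrogen in place of fluoro, and it has no readable size. Among the compounds with values here, no measured step therefore touches the chloro group, and none gives a size to carry over. The expectation rests only on both measured compounds sitting at the same limit in this assay. No step beyond the scatter is expected, in either direction, and the assay will probably report a limit again. The expected step is a number no higher from compound 2 to compound 3 (the limit leaves the size open). For compound 3 the estimated value is 100000 nM, with an expected range from 30000 nM to 300000 nM.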

Compound 3, half-maximal inhibitory concentration: 13500 nM
Compound 3: the middle estimate sits 7.4-fold (0.87 log units) above what was measured; measured number below the stated range.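

In this assay, the change from 4-chlorophenyl to 4-methoxyphenyl gives an at least 7.4-fold lower number from compound 2 to compound 3 (0.86 log units; beyond the scatter), so this aromatic carbon, para to a large group, is a place where a single substitution can bring the series into the measurable range. The earlier pair could not show this: the step from fluoro to hydrogen cannot be read, and it gave no sign that any part of the shared core could move the read-out. Going by these compounds alone, compound 3 therefore gives the first real number in this small set, while the other entries remain limits and not numbers, which means that the true size of the step stays open: the limit of > 100000 nM in this assay, at which 2 of the 3 values shown sit.

With only chloro and methoxy compared at this place, the compounds shown do not tell whether the oxygen, the added carbon or the loss of chloro accounts for the step, and a hydroxy, a methyl or an amine at the same carbon would help to separate these. They also leave open whether a longer chain such as ethoxy would lower the number further, and whether adding fluoro to compound 3, as in compound 1, would change its value.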